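Cytotoxicity on Vero cells: from amide to urea

A few compounds are considered here, and "the series" means these few. Any claim that something is new, unique, unknown or untested is made for them only; others in the source may bear on it.

Three compounds sharing one core were measured in an ADME assay on Vero cells (Chlorocebus sabaeus) for cytotoxicity, read by resazurin assay, with a stated time of 3 days; a lower number here means a stronger inhibitor, a higher number a weaker inhibitor. Compound 1 `CCCCOC(=O)Nc1cc2nc(C3CCCCC3)[nH]c2cc1N(C)C` carries a butoxy group on the carbonyl carbon. In this assay compound 1 gives > 100 ug/mL, which is a limit of the assay rather than a number. Compound 2 `CN(C)c1cc2[nH]c(C3CCCCC3)nc2cc1NC(=O)c1ccc(OC(F)F)cc1` carries 4-(difluoromethoxy)phenyl there. In this assay compound 2 gives > 100 ug/mL, again a limit. Compound 3 `CN(C)c1cc2[nH]c(C3CCCCC3)nc2cc1NC(=O)c1cccs1` carries thiophen-2-yl on the carbonyl carbon. In this assay compound 3 gives > 100 ug/mL, also a limit. Compound 3 therefore stands at the limit of the assay together with the other two, as shown by the limit of > 100 ug/mL in this assay, at which 3 of the 3 values shown sit. The steps between them, a step that the two limits leave unreadable from compound 1 to compound 2, a step that the two limits leave unreadable from compound 1 to compound 3 and a step that the two limits leave unreadable from compound 2 to compound 3, cannot be read in size because both ends are limits.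

Compound 4 `CCCCNC(=O)Nc1cc2nc(C3CCCCC3)[nH]c2cc1N(C)C` is not yet measured. It differs from compound 3 by butylamino in place of thiophen-2-yl on a carbonyl carbon. The measured steps that bear on this change all run between limits, so none of them gives a readable size, and they only show that three different groups on the carbonyl carbon all left the value at the limit. The step from compound 3 to compound 4 is therefore expected to be a step that the limit leaves unreadable from compound 3 to compound 4, with no direction beyond the scatter. For compound 4 in this assay the estimate is 150 ug/mL, with a range from 50 ug/mL to 400 ug/mL, most probably reported as a limit again.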

Compound 4, half-maximal inhibitory concentration: > 100 ug/mL
Compound 4 was reported as a limit; the forecaster's own chance of this, stated with the estimate: 85%; the middle value is on the limit's open side.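

In this assay compound 4 gives > 100 ug/mL, which is a limit of the assay and not a number. No step from compound 1, compound 2 or compound 3 to compound 4 can be read in size, because all of them end at one limit: the limit of > 100 ug/mL in this assay, at which 4 of the 4 values shown sit.

The compounds shown leave open whether the groups on the carbonyl carbon differ at all in this assay.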